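Aryl Amide Variation on the Shared Pyrazole-Free Core Series

The compounds below may be only part of what the source reports. "The series", "measured", "known", "first", "only" and "open" are said of these compounds alone.

Measured so far:
compound 1 `COc1cc(Cl)cc(-c2nn(-c3cccc(NC(=O)c4ccc(Cl)c(Cl)c4)c3)cc2-c2ccncc2)c1` — 43.5%
compound 2 `COc1cc(Cl)cc(-c2nn(-c3cccc(NC(=O)Nc4ccc(Cl)c(C(F)(F)F)c4)c3)cc2-c2ccncc2)c1` — 11.1%

In a functional assay on UO-31 cells (Homo sapiens) for inhibition, read by sulforhodamine B assay, with a stated time of 48 h, tested at 10 uM (on this read-out lower numbers stand for a stronger effect and higher numbers for a weaker effect at the one concentration tested), compound 1 gives 43.5% and stands as the higher of the two numbers; compound 2 gives 11.1%. For the measured compounds named here, the one measured step, a number 32.4 percentage points lower from compound 1 to compound 2 (beyond the scatter), is large and beyond the scatter, but it exchanges the whole group on the carbonyl carbon for one carrying an amino link, so it bears only in part on the change now considered.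

Compound 3 `COc1cc(Cl)cc(-c2nn(-c3cccc(NC(=O)c4cccc(C(F)(F)F)c4)c3)cc2-c2ccncc2)c1` differs from compound 1 by 3-(trifluoromethyl)phenyl in place of 3,4-dichlorophenyl on a carbonyl carbon. The amide is kept; only the aryl group changes. Going by the values given here, no measured step isolates this exchange, so the direction cannot be read from the data, and the size is uncertain. Among the compounds with values here, a modest step is expected, a number 5.5 percentage points lower from compound 1 to compound 3 (within the scatter), because a number 32.4 percentage points lower from compound 1 to compound 2 (beyond the scatter) is the only guide and arises from a broader change. Compound 3 is estimated at 38%, within 15% to 60%.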

Compound 3, a percentage reported as activity, at one concentration (the size of the read-out at that concentration, not a potency): 37.3%
For compound 3 the middle estimate is 0.7 percentage points above the measured one; low and high end bracket the measured number.
By their numbers in this assay, from the lowest: compound 2; then compounds 3 and 1 (each within the scatter of the next).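

In this assay, the exchange of 3,4-dichlorophenyl for 3-(trifluoromethyl)phenyl on the carbonyl carbon, with the amide kept, gives a number 6.2 percentage points lower from compound 1 to compound 3 (within the scatter), so at this position the two aryl groups cannot be told apart on this read-out. Putting 3-(trifluoromethyl)phenyl in place of (4-chloro-3-(trifluoromethyl)phenyl)amino gives a number 26.2 percentage points higher from compound 2 to compound 3 (beyond the scatter), which shows that the stronger effect of compound 2 is not reproduced by the trifluoromethyl group on an amide-linked aryl ring alone. No measurement at hand bears on the reason for either step.

Still open, from the compounds shown here alone, is how the difference divides between the amino link and the chloro substituent, a question that (3-(trifluoromethyl)phenyl)amino on the same carbonyl carbon would address. Also open, going by these compounds, is how a nitrile or a carboxylic acid on the aryl ring would read in this assay.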